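Swapping an amide for a sulfonamide on the shared core

A few compounds are considered here, and "the series" means these few. Any claim that something is new, unique, unknown or untested is made for them only; others in the source may bear on it.

This account follows three compounds on one shared core and a fourth not yet measured. In an ADME assay on microsomes from liver (Mus musculus) for metabolic stability, read by LC-MS, with a stated time of 60 min, tested at 10 uM (a higher number here means that the compound lasts longer, a lower number that the compound disappears faster), compound 1 `CCN(CC)S(=O)(=O)c1ccc(S(=O)(=O)N2CCC[C@@H](C(=O)NC3COC3)C2)cc1` gives 0.452 h, and compound 2 `CC(C)c1noc(C2CCN(C(=O)[C@@H]3CCCN(S(=O)(=O)c4ccc(S(=O)(=O)C(C)C)cc4)C3)CC2)n1` gives 0.543 h. Compound 3 `CCN(CC)C(=O)c1ccc(S(=O)(=O)N2CCC[C@@H](C(=O)N3CCN(c4nc(C(C)C)no4)CC3)C2)cc1` stands lowest of the three in this assay with 0.175 h, a step beyond the scatter below both compound 1 and compound 2.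

Compound 4 `CC(C)NS(=O)(=O)c1ccc(S(=O)(=O)N2CCC[C@@H](C(=O)N3CCN(c4nc(C(C)C)no4)CC3)C2)cc1` differs from compound 3 in one place: isopropylsulfamoyl in place of diethylcarbamoyl on an aromatic carbon. Among the measured compounds shown here, no pair of measured compounds differs in exactly this way, so the step has to be judged from the values alone. Compound 4 is expected to move upward in this assay, because compound 1 gives 0.452 h and compound 2 gives 0.543 h, both beyond the scatter above compound 3. The step from compound 3 to compound 4 is estimated at a 2.3-fold higher number from compound 3 to compound 4 (0.36 log units; beyond the scatter). The half-life of compound 4 in this assay is expected at 0.4 h, within a range from 0.2 h to 0.8 h.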

Compound 4, half-life: 0.489 h
Compound 4: middle estimate off by 1.2-fold (0.09 log units), on the low side, and the stated range covers the measured number.
By their numbers in this assay, from the lowest: compound 3; then compounds 1, 4 and 2 (each within the scatter of the next).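

In this assay, placing isopropylsulfamoyl in place of diethylcarbamoyl on this aromatic carbon gives a 2.8-fold higher number from compound 3 to compound 4 (0.45 log units; beyond the scatter), which shows that the half-life responds to the group at this position while the rest of the molecule stays the same. Among the compounds shown here, the two groups hold the same number of heavy atoms, yet the entering one carries a hydrogen-bond donor that the leaving one lacks, and the single step cannot tell which of their differences matters. Nothing measured here bears on why the half-life moves.

Going by these compounds, whether the step follows the sulfonyl or the isopropyl part of the entering group remains open. On these data alone, it is also open how isopropylcarbamoyl, which would pair the carbonyl with the isopropyl, or a carboxylic acid would fare at this position.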